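This account rests on a few compounds, and the source may have more. Where it says the series, first, only, none or still open, it means among the compounds named here.

Compound 3 `Cc1ccc(S(=O)(=O)NCc2ccc(CNC(=O)c3ccccc3Cl)cc2)cc1` gives 10 nM in an assay on MDA-MB-231 cells for binding affinity to C-X-C chemokine receptor type 4 (Homo sapiens), read by immunofluorescence and microscopy, with stated times of 10 min and 30 min (on this read-out higher numbers stand for an effect only at larger amounts of compound and lower numbers for an effect already at smaller amounts), and stands level with compound 1 `COc1cccc(C(=O)NCc2ccc(CNS(=O)(=O)c3ccc(C)cc3)cc2)c1` at 10 nM; together these are the lowest of the three numbers, while compound 2 `COc1ccc(C(=O)NCc2ccc(CNS(=O)(=O)c3ccc(C)cc3)cc2)cc1` gives 100 nM. Compound 4 `Cc1ccc(S(=O)(=O)NCc2ccc(CNC(=O)c3ccncc3)cc2)cc1` differs from compound 3 by pyridin-4-yl in place of 2-chlorophenyl on a carbonyl carbon. Among the measured compounds shown here, the steps that bear on this position are no change at the digits printed from compound 1 to compound 3 (within the scatter) and a 10-fold lower number from compound 2 to compound 3 (1.00 log units; beyond the scatter); none of the measured steps introduces an aromatic ring with a hetero atom at the carbonyl carbon, so the direction is open. For compound 4 in this assay a step within the scatter or a modest rise is expected, a 3.0-fold higher number from compound 3 to compound 4 (0.48 log units; beyond the scatter). Compound 4 is therefore estimated at 30 nM, with a range from 8 nM to 150 nM.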

Compound 4, effective concentration (reported as EC, without a stated level of effect): 10 nM
Compound 4: the middle estimate sits 3.0-fold (0.48 log units) above what was measured, and the stated range covers the measured number.
By their numbers in this assay, from the lowest: compounds 1, 3 and 4 (each within the scatter of the next); then compound 2.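

In this assay, among the compounds shown here, the pyridin-4-yl group is the first aromatic ring with a hetero atom on this carbonyl carbon, and it matches 2-chlorophenyl (no change at the digits printed from compound 3 to compound 4 (within the scatter)) and 3-methoxyphenyl (no change at the digits printed from compound 1 to compound 4 (within the scatter)), while the comparison with 4-methoxyphenyl gives (a 10-fold lower number from compound 2 to compound 4 (1.00 log units; beyond the scatter)). An aromatic ring of carbon only is therefore not required here for the low number. No measurement is available to explain this result. Going by these compounds, whether pyridin-3-yl or pyridin-2-yl would give the same number remains open. So does the outcome with a saturated ring such as piperidin-4-yl, or with a carboxylic acid or an aminomethyl group on the ring.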